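Trifluoroethoxy for isopropoxy on the aryl ether

A few compounds are considered here, and "the series" means these few. Any claim that something is new, unique, unknown or untested is made for them only; others in the source may bear on it.

Measured compounds:
compound 1, `CC(C)Oc1ccccc1N1CCN(CCN(C)C(=O)CN2CCCCC2=O)CC1`, 650 nM
compound 2, `CC(C)Oc1cc(F)ccc1N1CCN(CCNC(=O)CN2CCCCC2=O)CC1`, 4500 nM

Both numbers come from an assay on COS cells for binding affinity to Alpha-1D adrenergic receptor (Homo sapiens); on this read-out higher numbers stand for weaker inhibition and lower numbers for stronger inhibition. Compound 2 gives 4500 nM there, the higher of the two numbers, while compound 1 gives 650 nM, and the gap between the two lies beyond the scatter. Compound 1 and compound 2 differ in more than one place, so nothing can be read from their pair about any single change.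

Compound 3, `O=C(CN1CCCCC1=O)NCCN1CCN(c2ccc(F)cc2OCC(F)(F)F)CC1`, is not yet measured. It differs from compound 2 in one place: 2,2,2-trifluoroethyl in place of isopropyl on an oxygen on an aromatic ring. Within the data shown here, no measured pair shows this change, so there is no step to lean on. The account expects a step from compound 2 to compound 3 of a 1.3-fold lower number from compound 2 to compound 3 (0.11 log units; within the scatter) in this assay, which is no step beyond the scatter, in either direction. The estimate for compound 3 in this assay is 3500 nM, with a range from 1000 nM to 12000 nM.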

Compound 3, inhibition constant: 5350 nM
Beside the measured number, compound 3's estimate is 1.5-fold (0.18 log units) below it; low and high end bracket the measured number.
By their numbers in this assay, from the lowest: compound 1; then compounds 2 and 3 (each within the scatter of the next).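

In this assay the exchange of isopropyl for 2,2,2-trifluoroethyl on an oxygen on an aromatic ring gives a 1.2-fold higher number from compound 2 to compound 3 (0.08 log units; within the scatter) and so stays within the scatter. Among these compounds, the earlier pair differed in more than one place and could say nothing about this position, whereas this single change shows that, on the core of compound 2, the one ether group can stand for the other without a step beyond the scatter. Nothing measured here bears on why the two compounds read alike.

Still open, as far as these compounds go, is whether a methyl group or a longer chain such as n-butyl on that same oxygen would also stay within the scatter of compound 2. Also open, from the compounds shown here alone, is whether 2,2,2-trifluoroethyl would behave the same way on the core of compound 1, which differs from compound 2 in more than one place.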